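The source may report more compounds than this note shows. Statements on the series, on what has been measured and on what is new or still open speak of the compounds shown alone.

Measured compounds in an ADME assay on HaCaT cells (Homo sapiens) for cytotoxicity, read by MTT assay, with a stated time of 48 h; a higher number here means that more compound is needed for the effect, a lower number that less compound is needed:

Compound 1 `CCOC(=O)[C@@H](N)CCC(=O)NCCSC(=O)c1ccccc1` gives 331000 nM.
Compound 2 `CCOC(=O)[C@@H](N)CCC(=O)NCCSC(=O)C(C)(C)C` gives 228000 nM.
Compound 3 `CCCOC(=O)[C@@H](N)CCC(=O)NCCSC(=O)C(C)(C)C` gives 152000 nM.

All three numbers lie in a narrow band. The step of a 1.5-fold higher number from compound 2 to compound 1 (0.16 log units; within the scatter) and the step of a 1.5-fold lower number from compound 2 to compound 3 (0.18 log units; within the scatter) are both small. Compound 3 has the lowest number of the three, its gap to compound 1 being the only one beyond the scatter.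

Compound 4 `CCCOC(=O)[C@@H](N)CCC(=O)NCCSC(=O)c1ccccc1` has not been measured. It differs from compound 3 by phenyl in place of tert-butyl on a carbonyl carbon. The same change is made from compound 2 to compound 1, where it gave a 1.5-fold higher number from compound 2 to compound 1 (0.16 log units; within the scatter). The two cores differ by methyl in place of hydrogen on a saturated chain carbon, two bonds along the chain from an oxygen next to a carbonyl group, so the change is carried out on the propyl-ester core rather than the ethyl-ester core.

Within the data shown here, with only one earlier instance, the expectation for compound 4 rests on that single step: it is expected to follow a 1.5-fold higher number from compound 2 to compound 1 (0.16 log units; within the scatter), giving an estimated step of a 1.4-fold higher number from compound 3 to compound 4 (0.16 log units; within the scatter). Compound 4 is therefore estimated at 220000 nM in this assay, with a likely range from 120000 nM to 400000 nM.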

Compound 4, half-maximal effective concentration: 75000 nM
For compound 4 the middle estimate is 2.9-fold (0.47 log units) above the measured one; the whole stated range lies above it.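

On the core of compound 3, phenyl in place of tert-butyl on a carbonyl carbon gives a 2.0-fold lower number from compound 3 to compound 4 (0.31 log units; beyond the scatter), and this does not repeat the step seen on the other core: the same change on two cores in this assay, a 1.5-fold higher number (0.16 log units; within the scatter) from compound 2 to compound 1 and a 2.0-fold lower number (0.31 log units; beyond the scatter) from compound 3 to compound 4, 2.9-fold (0.47 log units) apart, beyond the scatter of two such steps

Read the other way, methyl in place of hydrogen on a saturated chain carbon, two bonds along the chain from an oxygen next to a carbonyl group, gives a 4.4-fold lower number from compound 1 to compound 4 (0.64 log units; beyond the scatter), which also departs from its earlier counterpart: the same change on two cores in this assay, a 1.5-fold lower number (0.18 log units; within the scatter) from compound 2 to compound 3 and a 4.4-fold lower number (0.64 log units; beyond the scatter) from compound 1 to compound 4, 2.9-fold (0.47 log units) apart, beyond the scatter of two such steps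

In these four compounds, the two changes therefore do not combine additively in this assay, but this rests on a single pair of cores and a single square of compounds, and it shows neither why the steps differ nor whether the same holds on other cores.

The compounds shown leave open how a chain longer than propyl in the ester would read in this assay. They also leave open whether a carboxylic acid in place of the ester, or acetyl in place of benzoyl, would follow the same course.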